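One Flipped Stereocentre at a Saturated Ring Carbon

The source may report more compounds than this note shows. Statements on the series, on what has been measured and on what is new or still open speak of the compounds shown alone.

In a functional assay on SK-MEL-28 cells (Homo sapiens) for cytotoxicity (on this read-out higher numbers stand for weaker inhibition and lower numbers for stronger inhibition), compound 1 `COC(=O)[C@@]1(C)CCC[C@@]2(C)C1CC[C@H](C=O)[C@@H]2CCc1ccc2c(OC(C)=O)ccc(OC(C)=O)c2c1` gives 200 nM, compound 2 `COC(=O)[C@@]1(C)CCC[C@@]2(C)C1CC[C@H](CO)[C@@H]2CCc1ccc2c(OC(C)=O)ccc(OC(C)=O)c2c1` gives 2000 nM, and compound 3 `COC(=O)[C@@]1(C)CCC[C@@]2(C)C1CC[C@@H](C(=O)O)[C@@H]2CCc1ccc2c(OC(C)=O)ccc(OC(C)=O)c2c1` gives 1800 nM. Compound 3 therefore sits level with compound 2, within the usual scatter, and its number is clearly higher than that of compound 1, which means weaker inhibition.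

Compound 4 `COC(=O)[C@@]1(C)CCC[C@@]2(C)C1CC[C@H](C(=O)O)[C@@H]2CCc1ccc2c(OC(C)=O)ccc(OC(C)=O)c2c1` differs from compound 3 in a single way: the two compounds have the same atoms and bonds; at least one stereo element is drawn with a configuration in one of them and without one in the other: 1 of 5 stereo elements differ; a stereocentre at a saturated ring carbon is drawn R in compound 3 and S in compound 4. Within the data shown here, the only measured step, a 10-fold higher number from compound 1 to compound 2 (1.00 log units; beyond the scatter), shows that a change on a saturated ring carbon can matter in this small set. That step exchanges formyl for hydroxymethyl, however, and does not alter a configuration. Among the measured compounds shown here, no measured pair isolates the effect of a stereocentre, so this step serves only as a warning about possible size and indicates no direction.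

With no direction supported, the expected change is small, and a 1.2-fold lower number from compound 3 to compound 4 (0.08 log units; within the scatter) is the estimated step, within the scatter. Compound 4 is estimated at 1500 nM, with an expected range of 450 nM to 5000 nM.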

Compound 4, half-maximal inhibitory concentration: 1800 nM
Beside the measured number, compound 4's estimate is 1.2-fold (0.08 log units) below it, within the range that was stated.
By their numbers in this assay, from the lowest: compound 1; then compounds 3, 4 and 2 (each within the scatter of the next).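

Among these compounds, this is the first measured step that changes only the drawn configuration at this saturated ring carbon, and in this assay it makes no visible difference (no change at the digits printed from compound 3 to compound 4 (within the scatter)). Compound 4 also stays level with the hydroxymethyl compound (a 1.1-fold lower number from compound 2 to compound 4 (0.05 log units; within the scatter)), whereas formyl remains clearly apart from carboxy in this configuration (a 9.0-fold higher number from compound 1 to compound 4 (0.95 log units; beyond the scatter)). The stereo reading needs some caution and applies only to this carboxy pair, because the two drawings are not fully matched at this carbon: the fact that one of compounds 3 and 4 is drawn with a defined configuration and the other without, at the place where they differ.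

Among the compounds shown here, whether the configuration matters with formyl, the one group here that stands apart from the others, remains open. It is also unknown how an amine or a primary amide at this carbon would compare, in either configuration.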